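Closing the amine into a seven-membered ring

This account rests on a few compounds, and the source may have more. Where it says the series, first, only, none or still open, it means among the compounds named here.

Compound 1 `CCCCN(C)c1nc(C(F)(F)F)ccc1CNC(=O)C(C)c1ccc(NS(C)(=O)=O)c(F)c1` was tested in a functional assay on CHO-K1 cells for antagonist activity at transient receptor potential cation channel subfamily V member 1 (Homo sapiens), read by FLIPR (a lower number here means a stronger inhibitor, a higher number a weaker inhibitor), where compound 1 gives 0.8 nM. This is the lower of the two numbers recorded so far. The other measured compound is compound 2 `CC(C(=O)NCc1ccc(C(F)(F)F)nc1N1CCC2(CC1)CC(c1ccccc1)=NO2)c1ccc(NS(C)(=O)=O)c(F)c1`, which carries a spirocyclic group in the same position of the shared core; in this assay compound 2 gives 6.1 nM, a weaker result that lies beyond the usual scatter when set against compound 1.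

Compound 3 `CC(C(=O)NCc1ccc(C(F)(F)F)nc1N1CCCCCC1)c1ccc(NS(C)(=O)=O)c(F)c1` has not yet been measured. It differs from compound 1 in one place: azepan-1-yl in place of butyl(methyl)amino on an aromatic carbon. The open chain attached to the ring nitrogen-bearing aromatic carbon is thus tied into a ring of similar size, while the rest of the molecule, including the amide and the sulfonamide-bearing aryl, is unchanged.

Among the compounds with values here, with no comparable pair among the measured compounds, the expectation is a small step, likely no larger than the scatter, and if anything toward a slightly weaker inhibitor; the estimated step of a 1.6-fold higher number from compound 1 to compound 3 (0.21 log units; within the scatter) reflects this. For compound 3 the estimate in this assay is 1.3 nM, with a range from 0.4 nM to 4.5 nM.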

Compound 3, inhibition constant: 0.8 nM
The estimate for compound 3 lay 1.6-fold (0.21 log units) above the measured number, and the stated range covers the measured number.
By their numbers in this assay, from the lowest: compounds 1 and 3 (each within the scatter of the next); then compound 2.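

In this assay, tying the butyl(methyl)amino chain into an azepan-1-yl ring gives no change at the digits printed from compound 1 to compound 3 (within the scatter), so this single change leaves the read-out where it was. The earlier numbers held no listed step between compounds differing in one place, whereas this pair gives a direct reading for this position, on an aromatic carbon next to the ring nitrogen: here an open chain and a seven-membered non-aromatic ring cannot be told apart. The data on hand give no explanation for why the two groups read alike.

This is one pair in one assay, so it cannot show whether the tolerance extends to other ring sizes, such as pyrrolidin-1-yl or piperidin-1-yl, or to a ring holding a second hetero atom, such as morpholin-4-yl. Nor can it show how far the open chain can be shortened, for example to dimethylamino, or whether the same equivalence between chain and ring would hold with a different group on the rest of the molecule.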